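Aryl variation on the ring nitrogen: notes toward compound 4

The source may hold more compounds than are shown below. What is called first, only, known or untested is meant among the compounds shown, and "the series" means these compounds.

Among the measured compounds shown here, compound 3 `CNC(=O)c1ccccc1Oc1nc(Nc2ccccc2OC)ncc1Br` is the only member of this set with a number in a functional assay on U-937 cells (Homo sapiens) for antiproliferative activity, read by MTT assay, with a stated time of 24 h; on this read-out lower numbers stand for stronger inhibition and higher numbers for weaker inhibition; in this assay compound 3 gives 52100 nM. For compound 1 `CNC(=O)c1ccccc1Oc1nc(Nc2ccc(C(F)(F)F)cc2)ncc1Br` this assay returns only a limit, > 50000 nM. For compound 2 `CNC(=O)c1ccccc1Oc1nc(Nc2ccccc2F)ncc1Br` this assay likewise returns only a limit, > 50000 nM. For the measured compounds named here, the single one-place step in the set, a step that the limit leaves unreadable from compound 2 to compound 3, cannot be read because of the limit of > 50000 nM in this assay, at which 2 of the 3 values shown sit.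

Compound 4 `CNC(=O)c1ccccc1Oc1nc(Nc2ccc(Cl)cc2F)ncc1Br` differs from compound 3 by 4-chloro-2-fluorophenyl in place of 2-methoxyphenyl on a nitrogen on an aromatic ring. Going by the values given here, no measured step bears directly on this change; the nearest comparison, compound 2 set against compound 3, spans a limit and a number close to that limit, so it gives neither direction nor size. The three values shown sit together at or about the limit, so the expectation for compound 4 in this assay is a value in the same region. Compound 4 is expected at 50000 nM, within a range of 20000 nM to 120000 nM. The expected step of a 1.0-fold lower number from compound 3 to compound 4 (0.02 log units; within the scatter) is estimated to lie within the scatter of the assay.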

Compound 4, half-maximal inhibitory concentration: > 50000 nM
Compound 4: only a limit was reported; the forecaster's own chance of this, stated with the estimate: 70%; the middle value lies on the limit itself.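

No new step can be read from compound 4 to compound 2 or compound 3, because all of these comparisons run into a limit: the limit of > 50000 nM in this assay, at which 3 of the 4 values shown sit.

The compounds shown leave open whether any aryl group on this nitrogen gives a value clear of that limit.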